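Amide series: amine variation at the aromatic carbon

The source may hold more compounds than are shown below. What is called first, only, known or untested is meant among the compounds shown, and "the series" means these compounds.

Measured so far in an assay on Sf9 cells for inhibition of Leucine-rich repeat serine/threonine-protein kinase 2 (Homo sapiens), read by TR-FRET, with stated times of 30 min and 2 h; a lower number here means a stronger inhibitor, a higher number a weaker inhibitor:
compound 1 `O=C(Nc1ccnnc1)c1cc(N2CCCC2)ccc1OCc1ccccc1` gives 20 nM
compound 2 `O=C(Nc1ccnnc1)c1cc(N2C[C@H]3COC[C@H]3C2)ccc1OCc1ccccc1` gives 50.1 nM
compound 3 `CN1CC2(CCN(c3ccc(OCc4ccccc4)c(C(=O)Nc4ccnnc4)c3)CC2)C1` gives 63.1 nM

Compound 3 stands highest of the three numbers; its gap to compound 2 lies within the scatter, whereas compound 1 gives a number clearly lower, as shown by a 3.2-fold higher number from compound 1 to compound 3 (0.50 log units; beyond the scatter) read in reverse.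

The next compound, compound 4 `N#CC1CCN(c2ccc(OCc3ccccc3)c(C(=O)Nc3ccnnc3)c2)CC1`, changes the group on the aromatic carbon once more: a group of 8 heavy atoms (6 carbon, 2 nitrogen; one six-membered non-aromatic ring with 1 hetero atom) in place of a group of 10 heavy atoms (8 carbon, 2 nitrogen; one four-membered non-aromatic ring with 1 hetero atom, one six-membered non-aromatic ring with 1 hetero atom), on an aromatic carbon

For the measured compounds named here, two measured steps bear on this position. Both a 2.5-fold higher number from compound 1 to compound 2 (0.40 log units; beyond the scatter) and a 3.2-fold higher number from compound 1 to compound 3 (0.50 log units; beyond the scatter) show that replacing the smallest group with a larger one gave higher numbers, while a 1.3-fold higher number from compound 2 to compound 3 (0.10 log units; within the scatter) shows no difference between the two larger groups. Compound 4 carries a group smaller than that of compound 3 yet larger than that of compound 1, so a modest step toward a lower number is expected, of the order of a 1.8-fold lower number from compound 3 to compound 4 (0.26 log units; within the scatter), and not a return to the number of compound 1. Compound 4 is therefore estimated at 35 nM, with a range of 15 nM to 80 nM.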

Compound 4, half-maximal inhibitory concentration: 10 nM
Compound 4: middle estimate off by 3.5-fold (0.54 log units), on the high side; the measured number lies below the stated range.
By their numbers in this assay, from the lowest: compounds 4 and 1 (each within the scatter of the next); then compounds 2 and 3 (each within the scatter of the next).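

In this assay the heavy-atom count of the group alone does not order this position. Compound 4 goes against the earlier trend of larger groups giving higher numbers: 4-cyanopiperidin-1-yl, although larger than pyrrolidin-1-yl, stays within the scatter of it (a 2.0-fold lower number from compound 1 to compound 4 (0.30 log units; within the scatter)), yet clearly separates from the group of compound 3 (a 6.3-fold lower number from compound 3 to compound 4 (0.80 log units; beyond the scatter)) and from the group of compound 2, which has the same heavy-atom count (a 5.0-fold lower number from compound 2 to compound 4 (0.70 log units; beyond the scatter)). No measurement at hand accounts for these differences.

Still open, going by these compounds, is whether the nitrile or the piperidine ring decides the result, a question that unsubstituted piperidin-1-yl, or a piperidine carrying a hydroxyl or a primary amide in place of the nitrile, would address. Also open, on these data alone, is whether the same order of groups holds with a methoxy group in place of the benzyloxy group.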